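A Methyl Moves Around the Saturated Ring

A few compounds are considered here, and "the series" means these few. Any claim that something is new, unique, unknown or untested is made for them only; others in the source may bear on it.

In a functional assay on DLD-1 cells (Homo sapiens) for cytotoxicity, read by WST assay, with a stated time of 72 h (a lower number here means a stronger inhibitor, a higher number a weaker inhibitor), compound 2 `COc1cc2c(Nc3nc4ccc(C(=O)Nc5c(C)cccc5Cl)cc4s3)ncnc2cc1OCCCN1CCCCC1` is the weaker of the two measured compounds: it gives 14700 nM, while compound 1 `COc1cc2c(Nc3nc4ccc(C(=O)Nc5c(C)cccc5Cl)cc4s3)ncnc2cc1OCCCN1CCCCC1C` gives 6700 nM. Going by the values given here, the only measured step, a 2.2-fold higher number from compound 1 to compound 2 (0.34 log units; beyond the scatter), replaces a methyl on a saturated ring carbon with hydrogen and makes the number higher. Compound 3 `COc1cc2c(Nc3nc4ccc(C(=O)Nc5c(C)cccc5Cl)cc4s3)ncnc2cc1OCCCN1CCC(C)CC1` reverses the sense of that change, but on another ring carbon: methyl in place of hydrogen on a saturated ring carbon. Among the compounds with values here, that single step is the only evidence that bears on the question, and it suggests a methyl on this ring brings a modest lowering of the number; since the methyl of compound 1 sat on a carbon other than the one used here, the evidence is thin. A modest decrease is nonetheless expected, a 1.6-fold lower number from compound 2 to compound 3 (0.21 log units; within the scatter). Compound 3 is estimated at 9000 nM, most likely between 4000 nM and 22000 nM.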

Compound 3, half-maximal inhibitory concentration: 11300 nM
Compound 3: middle estimate off by 1.3-fold (0.10 log units), on the low side; low and high end bracket the measured number.
By their numbers in this assay, from the lowest: compounds 1, 3 and 2 (each within the scatter of the next, the first and the last beyond it).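

In this assay, placing the methyl three ring bonds from the ring nitrogen, the change from piperidin-1-yl to 4-methylpiperidin-1-yl, gives a 1.3-fold lower number from compound 2 to compound 3 (0.11 log units; within the scatter) and stays within the scatter, so at this position the methyl cannot be told apart from hydrogen. Moving the methyl from the 2-methylpiperidin-1-yl group to this ring carbon gives a 1.7-fold higher number from compound 1 to compound 3 (0.23 log units; within the scatter) and also stays within the scatter, so the two methyl positions cannot be separated either, even though only compound 1 and compound 2 lie beyond the scatter of each other. No measurement here offers an explanation for these small steps. On these data alone, whether an ethyl or a hydroxyl on this same ring carbon would move the number further remains open. So does the result of replacing the piperidine with a morpholine.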